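This account rests on a few compounds, and the source may have more. Where it says the series, first, only, none or still open, it means among the compounds named here.

Compound 1, with structure `CCCCNC(=S)NCc1ccccc1`, is a thiourea bearing a butylamino group on one side and a benzylamino group on the other. In a functional assay on RAW264.7 cells (Mus musculus) for inhibition, read by Griess assay, with a stated time of 24 h (a higher number here means a weaker inhibitor, a lower number a stronger inhibitor), compound 1 gives 143000 nM, the highest number among the two compounds measured, which marks it as the weaker of the pair. Going by the values given here, the only other measured compound, compound 2, has structure `O=C(O)c1ccc(NC(=S)NCc2ccccc2)cc1O` and in this assay compound 2 gives 8100 nM, a gap that lies beyond the usual scatter; compound 2 differs from compound 1 in more than one place, so no single change can be read from that comparison.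

Compound 3, with structure `CCN(CC)C(=S)NCc1ccccc1`, is the partner of interest. The two structures are made of the same atoms joined differently, and the change is diethylamino in place of butylamino on a thiocarbonyl carbon. Among the compounds with values here, no measured pair shows this particular change, so there is nothing to lean on beyond the starting value of compound 1. The step is expected to be small and is estimated as a 1.3-fold higher number from compound 1 to compound 3 (0.10 log units; within the scatter), most likely not beyond the scatter. Compound 3 is therefore estimated at 180000 nM, with a range from 60000 nM to 550000 nM.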

Compound 3, half-maximal inhibitory concentration: 15700 nM
Beside the measured number, compound 3's estimate is 11-fold (1.06 log units) above it; measured number outside the range, below it.
By their numbers in this assay, from the lowest: compounds 2 and 3 (each within the scatter of the next); then compound 1.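

The change brings a 9.1-fold lower number from compound 1 to compound 3 (0.96 log units; beyond the scatter) in this assay, so this place on a thiocarbonyl carbon responds to how the same atoms are joined and not only to which atoms are present. Butylamino and diethylamino both have 5 heavy atoms (4 carbon, 1 nitrogen), and the count that separates them is 1 hydrogen-bond donor for butylamino against 0 hydrogen-bond donors for diethylamino; this is the first single-place comparison in the set, since the earlier compounds differ in more than one place. That difference in count is only a description of the two groups, and nothing available here shows what lies behind the lower number.

The compounds shown leave open whether dimethylamino, a longer chain such as hexylamino, or a piperidine ring on the same thiocarbonyl carbon would follow diethylamino or butylamino, so a single pair cannot yet separate the effect of branching from that of losing the hydrogen-bond donor. On these data alone, whether the same exchange would give a step of similar size on a different core also remains unknown.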